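Furanyl, cyclohexyl and para-substituted phenyl acetals: cytotoxicity notes

This account rests on a few compounds, and the source may have more. Where it says the series, first, only, none or still open, it means among the compounds named here.

Measured in a functional assay on HEL cells (Homo sapiens) for cytotoxicity; on this read-out lower numbers stand for higher toxicity in this test and higher numbers for lower toxicity in this test:
- compound 1 `CO[C@@H]1[C@@H](OC)[C@H](c2ccccc2)O[C@@H]2CO[C@@H](c3ccco3)O[C@@H]12`: "not determined" (no result reported)
- compound 2 `CO[C@@H]1[C@@H](OC)[C@H](c2ccccc2)O[C@@H]2CO[C@@H](C3CCCCC3)O[C@@H]12`: gives 20 ug/mL
- compound 3 `CO[C@@H]1[C@@H](OC)[C@H](c2ccccc2)O[C@@H]2CO[C@@H](c3ccc([N+](=O)[O-])cc3)O[C@@H]12`: "not determined" (no result reported)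

For the measured compounds named here, compound 3 stands without a single number in this assay; compound 1 is a further entry without one, so compound 2 is the only compound of the series with a value in this assay. Compound 4 `CO[C@@H]1[C@@H](OC)[C@H](c2ccccc2)O[C@@H]2CO[C@@H](c3ccc(C(F)(F)F)cc3)O[C@@H]12` is the unmeasured member. It differs from compound 3 by trifluoromethyl in place of nitro on an aromatic carbon. Going by the values given here, no measured pair differing in one place exists, so the size of this step in this assay cannot be read from the data; with nothing to anchor a direction, no step beyond the usual scatter is expected, and the series is taken to sit near the one value in hand. Compound 4 is therefore expected to give about 20 ug/mL in this assay, within a range of 4 ug/mL to 100 ug/mL, because compound 2 gives 20 ug/mL as the only point of reference.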

Compound 4, minimum cytotoxic concentration: >= 16 ug/mL
Compound 4 ended at the assay's limit (the forecaster's own chance of this, stated with the estimate: 40%); the middle value lies beyond the limit too.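

In this assay compound 4 gives >= 16 ug/mL, which is a limit of the assay and not a number. No step from compound 2 to compound 4 can therefore be read: the limit of >= 16 ug/mL in this assay, at which 1 of the 4 values shown sits.

On these data alone, whether 4-(trifluoromethyl)phenyl in place of cyclohexyl shifts the result in this assay at all stays open.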